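The source may report more compounds than this note shows. Statements on the series, on what has been measured and on what is new or still open speak of the compounds shown alone.

Compound 1 `CCc1ccc(-c2ccc3ncc(-c4noc(C)n4)cc3c2)cc1` and compound 2 `CCc1ccc(-c2ccc3ncc(-c4noc(CC)n4)cc3c2)cc1` share one core. In a functional assay on RD cells (Homo sapiens) for inhibition, read by luminescence and ATP content, with a stated time of 72 h (a higher number here means that more compound is tolerated, a lower number that less compound is tolerated), compound 1 gives only a limit of the assay, > 7400 nM. In this assay compound 2 also gives only a limit, > 22200 nM. Among the measured compounds shown here, compound 2 therefore stands at the limit of > 22200 nM in this assay, at which 1 of the 2 values shown sits, without a number of its own, and the one measured step, a step that the two limits leave unreadable from compound 1 to compound 2, cannot be sized. Compound 3 `CCc1nc(-c2cnc3ccc(-c4ccc(NC(C)=O)cc4)cc3c2)no1` carries acetamido in place of ethyl on an aromatic carbon, acetamido in place of ethyl on an aromatic carbon. With no readable step to lean on, the tolerated amount for compound 3 is expected to remain high, a step that the limit leaves unreadable from compound 2 to compound 3. Compound 3 is expected at 25000 nM, between 8000 nM and 80000 nM.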

Compound 3, half-maximal cytotoxic concentration: > 7400 nM
Compound 3 gave a limit, no number; the forecaster's own chance of this, stated with the estimate: 80%; the middle value lies beyond the limit too.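

Among the compounds shown here, compound 3 gives only a limit in this assay, > 7400 nM, so no step from compound 2 to compound 3 can be read. The compounds shown leave open where the actual half-maximal cytotoxic concentration of any of the three lies.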